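The source may hold more compounds than are shown below. What is called first, only, known or untested is meant among the compounds shown, and "the series" means these compounds.

In a functional assay on MDA-MB-231 cells (Homo sapiens) for antiproliferative activity, read by MTT assay, with a stated time of 72 h (on this read-out higher numbers stand for weaker inhibition and lower numbers for stronger inhibition), compound 1 (`C#Cc1cccc(NC(=O)CCc2cccc3c2B(O)OC3)c1`) gives 1600 nM and compound 2 (`COc1ccccc1NC(=O)CCc1cccc2c1B(O)OC2`) gives 930 nM. Among the compounds with values here, compound 1 therefore stands within the usual scatter of compound 2, the only other measured compound. Compound 3 (`COc1ccc(-c2cccc(NC(=O)CCc3cccc4c3B(O)OC4)c2)cc1`) has 4-methoxyphenyl in place of ethynyl on an aromatic carbon of compound 1: 4-methoxyphenyl in place of ethynyl on an aromatic carbon. Within the data shown here, no step at a single place has yet been measured in this assay, so no change beyond the scatter is expected, in either direction. The expected step, a 1.3-fold lower number from compound 1 to compound 3 (0.12 log units; within the scatter), is only an estimate. For compound 3 the estimated value is 1200 nM, with an expected range of 400 nM to 3500 nM.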

Compound 3, half-maximal inhibitory concentration: 88 nM
Estimate against measurement, compound 3: 14-fold (1.13 log units) above, outside the stated range (below it).
By their numbers in this assay, from the lowest: compound 3; then compounds 2 and 1 (each within the scatter of the next).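

In this assay, 4-methoxyphenyl in place of ethynyl on this aromatic carbon, meta to a large group, gives an 18-fold lower number from compound 1 to compound 3 (1.26 log units; beyond the scatter). Within the data shown here, this is the first step at a single place, and it shows that the position accepts a six-membered aromatic ring and that the read-out responds strongly to the change there. Nothing available accounts for the size of this step.

The compounds shown leave open whether the ring itself or its methoxy group carries the step. They also leave open how plain phenyl, an amine or a carboxylic acid would read at the same carbon.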